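Isopentyloxy to Hexyloxy: How Much Further Down?

This account rests on a few compounds, and the source may have more. Where it says the series, first, only, none or still open, it means among the compounds named here.

In a functional assay on brain (Rattus norvegicus, strain Wistar) for inhibition (on this read-out higher numbers stand for weaker inhibition and lower numbers for stronger inhibition), compound 1 `COc1ccc(-c2c(C)[nH]c(=O)n2C)cc1`, with methyl on an oxygen on an aromatic ring, gives 147000 nM. Compound 2 `Cc1[nH]c(=O)n(C)c1-c1ccc(OC(C)C)cc1`, with isopropyl on that oxygen, gives 20400 nM, and compound 3 `Cc1[nH]c(=O)n(C)c1-c1ccc(OCCC(C)C)cc1`, with isopentyl there, gives 6600 nM. Compound 3 therefore holds the lowest number of the three, making it the strongest inhibitor measured so far.

Compound 4 `CCCCCCOc1ccc(-c2c(C)[nH]c(=O)n2C)cc1` keeps the shared core and alters only the chain: butyl in place of isopropyl on a saturated chain carbon, two bonds along the chain from an oxygen on an aromatic ring. Read one bond further out, isopentyloxy becomes hexyloxy.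

For the measured compounds named here, three measured steps bear on this change. Larger groups on the oxygen have so far gone with lower numbers, with no compound here going against that: a 7.2-fold lower number from compound 1 to compound 2 (0.86 log units; beyond the scatter), then a 3.1-fold lower number from compound 2 to compound 3 (0.49 log units; beyond the scatter), and overall a 22-fold lower number from compound 1 to compound 3 (1.35 log units; beyond the scatter). The step to the isopentyl group is the smaller of the first two, so any further gain may well be modest. Going by the values given here, no measured pair shows a branched chain exchanged for a straight one, which adds uncertainty.

In this assay a small move towards stronger inhibition is therefore expected, possibly no larger than the usual scatter. The expected step is a 1.7-fold lower number from compound 3 to compound 4 (0.24 log units; within the scatter). For compound 4 the estimated value is 3800 nM, with an expected range from 1400 nM to 10000 nM.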

Compound 4, half-maximal inhibitory concentration: 7300 nM
The estimate for compound 4 lay 1.9-fold (0.28 log units) below the measured number; the measured number falls inside the stated range.
By their numbers in this assay, from the lowest: compounds 3 and 4 (each within the scatter of the next); then compound 2; then compound 1.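

In this assay, the straight hexyl chain and the branched isopentyl chain cannot be told apart, with a 1.1-fold higher number from compound 3 to compound 4 (0.04 log units; within the scatter): at this place, two bonds along the chain from an oxygen on an aromatic ring, butyl in place of isopropyl gives no readable step, so the run of lower numbers that came with larger groups on the oxygen does not carry on to compound 4. The gain over the smaller groups is kept, with a 2.8-fold lower number from compound 2 to compound 4 (0.45 log units; beyond the scatter) and a 20-fold lower number from compound 1 to compound 4 (1.30 log units; beyond the scatter), which leaves compound 3 and compound 4 together at the low end of the series, so adding size to the group on the oxygen pays off up to isopentyl but shows nothing further at hexyl. Nothing available explains why the numbers stop falling here.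

On these data alone, whether a longer chain such as octyl would stay level with compound 4 or lose ground remains open, as does the question of whether branching matters at all, which a straight pentyl chain could help to answer. Also open, as far as these compounds go, is how this place would respond to a ring such as cyclohexyl, or to a chain ending in an amine or a carboxylic acid.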